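This account rests on a few compounds, and the source may have more. Where it says the series, first, only, none or still open, it means among the compounds named here.

In a functional assay on THP-1 cells (Homo sapiens) for inhibition, read by ELISA, with stated times of 2 h and 48 h (on this read-out lower numbers stand for stronger inhibition and higher numbers for weaker inhibition), compound 1 (`[O-]/[N+](=C\c1cn(-c2ccc(F)cc2)nn1)c1ccccc1`) gives > 20000 nM, which is a limit of the assay and not a number. Among the compounds with values here, compound 2 (`[O-]/[N+](=C\c1cn(-c2ccc(F)cc2)nn1)Cc1ccccc1`) gives 9700 nM, the only actual number so far. Within the data shown here, the one measured step, an at least 2.0-fold lower number from compound 1 to compound 2 (0.31 log units; beyond the scatter), came with benzyl in place of phenyl on a double-bonded nitrogen.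

Compound 3 (`[O-]/[N+](=C\c1cn(-c2ccc(C(F)(F)F)cc2)nn1)Cc1ccccc1`) keeps the benzyl and changes the other end of the molecule: trifluoromethyl in place of fluoro on an aromatic carbon. This is trifluoromethyl in place of fluoro on an aromatic carbon, para to a large group. The step of an at least 2.0-fold lower number from compound 1 to compound 2 (0.31 log units; beyond the scatter) was made elsewhere in the molecule, so it shows that numbers in this assay can move within this small set, but it gives neither the size nor the direction for the new change. Among the measured compounds shown here, no measured step touches this position, so the expectation is a small change, not clearly beyond the scatter, with either direction possible. The expected change is a 1.2-fold lower number from compound 2 to compound 3 (0.08 log units; within the scatter). For compound 3 the estimated value is 8000 nM, with an expected range from 3000 nM to 20000 nM.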

Compound 3, half-maximal inhibitory concentration: 15400 nM
For compound 3 the middle estimate is 1.9-fold (0.28 log units) below the measured one, and the stated range covers the measured number.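

In this assay, within the data shown here, the first look at this position comes from trifluoromethyl in place of fluoro on an aromatic carbon, para to a large group, which gives a 1.6-fold higher number from compound 2 to compound 3 (0.20 log units; within the scatter). Although the entering group has 4 heavy atoms and the leaving group has 1, compound 2 and compound 3 cannot be told apart on this read-out, so this one exchange does not produce a change beyond the usual scatter. The reading comes with a caution, since the only other compound in the set has no exact number and the measurable range ends at a limit: the limit of > 20000 nM in this assay, at which 1 of the 3 values shown sits.

The compounds shown use only two groups at this position, so an amine, a carboxylic acid or a methoxy group there remains an open case, and one pair of compounds cannot show a trend for this place on the ring. It also remains open whether the benefit of benzyl over phenyl on the double-bonded nitrogen would hold with trifluoromethyl at the other end, as the phenyl and benzyl pair shown carries fluoro.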